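Spirooxindole–pyran series: aryl swap on the triazole nitrogen

The source may report more compounds than this note shows. Statements on the series, on what has been measured and on what is new or still open speak of the compounds shown alone.

Measured so far:
Compound 1 `N#CC1=C(N)Oc2c(c3nc4ccccc4nc3c3ccccc23)C12C(=O)N(Cc1cnnn1-c1cccc(Cl)c1)c1ccccc12`: 32600 nM
Compound 2 `N#CC1=C(N)Oc2c(c3nc4ccccc4nc3c3ccccc23)C12C(=O)N(Cc1cnnn1-c1cccc(S(N)(=O)=O)c1)c1ccccc12`: 44200 nM
Compound 3 `Cc1ccc(-n2nncc2CN2C(=O)C3(C(C#N)=C(N)Oc4c(N)cc5nc6ccccc6nc5c43)c3ccccc32)cc1C`: > 50000 nM

In a functional assay on A549 cells (Homo sapiens) for antiproliferative activity, read by MTT assay, with a stated time of 48 h (a higher number here means a weaker inhibitor, a lower number a stronger inhibitor), compound 1 gives 32600 nM. Compound 2, which carries sulfamoyl in place of chloro on the aromatic carbon, gives 44200 nM in this assay; the step of a 1.4-fold higher number from compound 1 to compound 2 (0.13 log units; within the scatter) does not leave the scatter. For compound 3 this assay reports only a limit, > 50000 nM, and no number; this is the limit described by the limit of > 50000 nM in this assay, at which 1 of the 3 values shown sits. Compound 3 therefore stands at the weak end of the values seen so far, with no number of its own to compare.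

Compound 4 `N#CC1=C(N)Oc2c(N)cc3nc4ccccc4nc3c2C12C(=O)N(Cc1cnnn1-c1c(Cl)cc(Cl)cc1Cl)c1ccccc12` is not yet measured. It differs from compound 3 by 2,4,6-trichlorophenyl in place of 3,4-dimethylphenyl on an aromatic nitrogen. Among the compounds with values here, the only measured step that touches the group on the aromatic nitrogen is the one from compound 1 to compound 2, and that step stayed within the scatter. Within the data shown here, no measured step exchanges a dimethyl-bearing phenyl for a trichloro-bearing one, so the direction of the change is not fixed by the data.

Compound 4 is expected to remain close to the limit at which compound 3 sits, with a step of a number no higher from compound 3 to compound 4 (the limit leaves the size open) of no clear size in this assay. The estimate for compound 4 is 50000 nM, in the range 20000 nM to 120000 nM, with a real chance that this assay again returns only a limit.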

Compound 4, half-maximal inhibitory concentration: > 50000 nM
Compound 4 was reported as a limit (the forecaster's own chance of this, stated with the estimate: 55%); the middle value sits exactly at the limit.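

Within the data shown here, compound 4, like compound 3, returns only a limit in this assay, so no step between the two can be read. Both stand at the same reported limit: the limit of > 50000 nM in this assay, at which 2 of the 4 values shown sit.

The compounds shown leave open how 2,4,6-trichlorophenyl and 3,4-dimethylphenyl on the aromatic nitrogen actually compare on this core, and whether either group changes the activity at all.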